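The source may hold more compounds than are shown below. What is called first, only, known or untested is meant among the compounds shown, and "the series" means these compounds.

Going by the values given here, in a functional assay for inhibition, with Cavia porcellus as the target (on this read-out higher numbers stand for weaker inhibition and lower numbers for stronger inhibition), compound 1 (`COc1ccc(C(=O)Nc2ccccc2Cl)cc1OC1CCCC1`) gives 450 nM and compound 2 (`COc1ccc(C(=O)Nc2c(F)cccc2F)cc1OC1CCCC1`) gives 580 nM, so compound 2 stands within the scatter of the only other number. Compound 3 (`COc1ccc(C(=O)Nc2ccncc2Cl)cc1OC1CCCC1`) has 3-chloropyridin-4-yl in place of 2,6-difluorophenyl on an amide-type nitrogen. Among the compounds with values here, the one measured step, a 1.3-fold higher number from compound 1 to compound 2 (0.11 log units; within the scatter), changes the group at that same place, but neither of its rings holds a hetero atom, so it bears only loosely. No step beyond the scatter is expected in this assay, and the data fix no direction. The expected step is a 1.7-fold lower number from compound 2 to compound 3 (0.22 log units; within the scatter). The estimate for compound 3 is 350 nM, with an expected range of 90 nM to 1100 nM.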

Compound 3, half-maximal inhibitory concentration: 30 nM
For compound 3 the middle estimate is 12-fold (1.07 log units) above the measured one; measured number below the stated range.
By their numbers in this assay, from the lowest: compound 3; then compounds 1 and 2 (each within the scatter of the next).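

On an amide-type nitrogen, this assay proves sensitive to the group: 3-chloropyridin-4-yl brings a 19-fold lower number from compound 2 to compound 3 (1.29 log units; beyond the scatter) and a 15-fold lower number from compound 1 to compound 3 (1.18 log units; beyond the scatter), while the two groups with an aromatic ring of carbon only stay within the scatter of each other. The larger change appears only with a ring that holds a hetero atom and a hydrogen-bond acceptor, and the chlorine is present in both compound 1 and compound 3. Nothing available explains the size of these steps.

From the compounds shown here alone, whether the ring nitrogen suffices without the chlorine remains open. So does whether bromine or a methyl group in place of that chlorine would keep the number this low.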